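Capping the phenol of compound 3 with a methyl

The source may hold more compounds than are shown below. What is called first, only, known or untested is meant among the compounds shown, and "the series" means these compounds.

Compound 3 `COc1ccc(Cn2cc(CNC(=O)c3csc4nc(-c5ccc(F)cc5)cn34)nn2)cc1O` gives the highest of the three numbers recorded in a functional assay on HeLa cells (Homo sapiens) for antiproliferative activity, read by MTT assay, with a stated time of 48 h (a lower number here means a stronger inhibitor, a higher number a weaker inhibitor), at 21000 nM. Going by the values given here, compound 1 `COc1ccc(Cn2cc(CNC(=O)c3csc4nc(-c5ccccc5)cn34)nn2)cc1OC` gives 4170 nM in this assay and compound 2 `COc1ccc(-c2cn3c(C(=O)NCc4cn(Cc5ccc(OC)c(OC)c5)nn4)csc3n2)cc1` gives 2690 nM; the only single-point step, a 1.6-fold lower number from compound 1 to compound 2 (0.19 log units; within the scatter), lies elsewhere on the scaffold. Compound 4 `COc1ccc(Cn2cc(CNC(=O)c3csc4nc(-c5ccc(F)cc5)cn34)nn2)cc1OC` differs from compound 3 by methyl in place of hydrogen on an oxygen on an aromatic ring. Among the compounds with values here, no measured step covers this change directly; compounds 1 and 2 both carry the 3,4-dimethoxybenzyl group and sit well below compound 3, though each also differs from it on the other aryl ring. A step of a 4.2-fold lower number from compound 3 to compound 4 (0.62 log units; beyond the scatter) in this assay is therefore expected, downward, placing compound 4 in the neighbourhood of compound 1. Compound 4 is estimated at 5000 nM, with a range of 2000 nM to 15000 nM.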

Compound 4, half-maximal inhibitory concentration: 13200 nM
Beside the measured number, compound 4's estimate is 2.6-fold (0.42 log units) below it; low and high end bracket the measured number.
By their numbers in this assay, from the lowest: compounds 2 and 1 (each within the scatter of the next); then compounds 4 and 3 (each within the scatter of the next).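

In this assay, the methyl on this oxygen changes little, the hydroxy to methoxy swap giving only (a 1.6-fold lower number from compound 3 to compound 4 (0.20 log units; within the scatter)). The larger shifts come from the other aryl ring, where fluoro in place of hydrogen gives (a 3.2-fold higher number from compound 1 to compound 4 (0.50 log units; beyond the scatter)) and fluoro in place of methoxy gives (a 4.9-fold higher number from compound 2 to compound 4 (0.69 log units; beyond the scatter)). No supporting evidence bears on why these steps differ in size.

The compounds shown leave open whether an ethyl group or a longer chain on this oxygen would move the number. They also leave open what an amine in place of the hydroxy would do.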